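The source may report more compounds than this note shows. Statements on the series, on what has been measured and on what is new or still open speak of the compounds shown alone.

Three compounds carry the same core, a pyridine-type ring bearing a naphthyl group, and differ only in the side chain on the ring carbon. Compound 1 `CNC(=O)/C=C/c1ccncc1-c1ccc2ccccc2c1` gives 101% in an assay on a protein complex for inhibition of CDK8/Cyclin C (Homo sapiens), with a stated time of 1 h, tested at 10 uM; on this read-out lower numbers stand for less inhibition and higher numbers for more inhibition at the one concentration tested (going by the name of the read-out). Compound 2 `NNC(=O)COc1ccncc1-c1ccc2ccccc2c1` gives 19% in this assay. Compound 3 `O=C(O)/C=C/c1ccncc1-c1ccc2ccccc2c1` gives 102% in this assay, which places it at the top of the three numbers, though its gap to compound 1 is within the scatter and only compound 2 lies clearly below it.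

Compound 4 `O=C(O)CCc1ccncc1-c1ccc2ccccc2c1` is not yet measured. It differs from compound 3 as follows: 2-carboxyethyl in place of 2-carboxyethenyl on an aromatic carbon.

Going by the values given here, no measured step tests this particular change. The step of a number 1 percentage points higher from compound 1 to compound 3 (within the scatter) shows that swapping the group on the carbonyl leaves the number where it was, while a number 83 percentage points higher from compound 2 to compound 3 (beyond the scatter) shows that exchanging the whole side chain can move the number a great deal. The present change keeps the carboxylic acid and alters only the linker, so a drop in this assay is possible but its size is uncertain. The expected step is a number 42 percentage points lower from compound 3 to compound 4 (beyond the scatter), giving compound 4 an estimated 60% in this assay, between 15% and 95%.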

Compound 4, a percentage reported as inhibition, at one concentration (the size of the read-out at that concentration, not a potency): 101%
Estimate against measurement, compound 4: 41 percentage points below, and the stated range ends below it.
By their numbers in this assay, from the lowest: compound 2; then compounds 1, 4 and 3 (each within the scatter of the next).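

In this assay, replacing 2-carboxyethenyl with 2-carboxyethyl gives a number 1 percentage points lower from compound 3 to compound 4 (within the scatter), so at this position the double bond in the linker makes no difference beyond the scatter at the one concentration tested. The acid with the saturated linker also matches the unsaturated methyl amide, with no change at the digits printed from compound 1 to compound 4 (within the scatter), whereas the (aminocarbamoyl)methoxy side chain stands well apart, with a number 82 percentage points higher from compound 2 to compound 4 (beyond the scatter). Nothing available here accounts for these similarities or for that gap.

Going by these compounds, because each compound has only a single-concentration reading, it remains open whether compounds 1, 3 and 4 would separate at lower concentrations. On these data alone, it is also open how a shorter carboxymethyl group, a longer 3-carboxypropyl chain or an amine at the end of the chain would behave at this position.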